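From quinolin-2-yl to pyridin-4-yl on a shared core

The source may report more compounds than this note shows. Statements on the series, on what has been measured and on what is new or still open speak of the compounds shown alone.

In a physicochemical assay for lipophilicity (on this read-out lower numbers stand for lower lipophilicity and higher numbers for higher lipophilicity), compound 2 (`CN(C)c1ccc(C(=O)OCC2(CO)C/C(=C\c3ccc4ccccc4n3)C(=O)O2)cc1`) gives 3.22, level with compound 1 (`CN(C)c1ccc(C(=O)OCC2(CO)C/C(=C/c3ccc4ccccc4n3)C(=O)O2)cc1`) at 3.22, while compound 3 (`CCCC(CCC)C(=O)OCC1(CO)C/C(=C\c2cccnc2)C(=O)O1`) lies lower at 2.9. Compound 4 (`CN(C)c1ccc(C(=O)OCC2(CO)C/C(=C\c3ccncc3)C(=O)O2)cc1`) departs from compound 2 by one change: pyridin-4-yl in place of quinolin-2-yl on a double-bonded chain carbon bound to a double-bonded ring carbon. Going by the values given here, the only measured step, no change at the digits printed from compound 1 to compound 2 (within the scatter), concerns the drawn double bond and leaves the aromatic group untouched, so it sets no size for this swap. Compound 3, at 2.9, differs in more than one place and serves only as a loose guide. With a carbon-only aromatic ring gone, a clear fall beyond the scatter in this assay is expected. The expected step is a number 1.12 log units lower from compound 2 to compound 4 (beyond the scatter). For compound 4 the estimate is 2.1, within an expected range of 1.6 to 2.7.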

Compound 4, partition coefficient: 2.07
For compound 4 the middle estimate is 0.03 log units above the measured one, within the range that was stated.
By their numbers in this assay, from the lowest: compound 4; then compound 3; then compounds 1 and 2 (each within the scatter of the next).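

Going by these compounds alone, compound 4 gives the first measured step at this place that involves the aromatic group, on a double-bonded chain carbon bound to a double-bonded ring carbon. In this assay, that group matters far more than the drawn double bond: a number 1.15 log units lower from compound 2 to compound 4 (beyond the scatter), against no change at the digits printed from compound 1 to compound 2 (within the scatter). Nothing on record accounts for the size of this step.

The swap removes the carbon-only aromatic ring and also moves the attachment on the ring that holds the nitrogen, so the two changes stay unseparated. A pyridin-2-yl or phenyl group at the same place would tell them apart.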